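Amide nitrogen substituents on the shared core

The source may hold more compounds than are shown below. What is called first, only, known or untested is meant among the compounds shown, and "the series" means these compounds.

Compound 1 `CNC(=O)c1ccncc1Nc1cc(-c2ccc3ccn(C)c3c2)c2nccnc2c1` gives 83 nM in an assay for inhibition of 6-phosphofructo-2-kinase/fructose-2,6-bisphosphatase 3 (Homo sapiens), read by ADP-Glo, with a stated time of 2 h; on this read-out lower numbers stand for stronger inhibition and higher numbers for weaker inhibition. Compound 2 `Cn1ccc2ccc(-c3cc(Nc4cnccc4C(=O)NC4CCNC(=O)C4)cc4nccnc34)cc21` gives 69 nM and compound 3 `CN1CC(NC(=O)c2ccncc2Nc2cc(-c3ccc4ccn(C)c4c3)c3nccnc3c2)CCC1=O` gives 116 nM; compound 1 stands second highest of the three, nearest compound 2 and furthest from compound 3, all three within the scatter of one another. Compound 4 `CN1CCC(N(C)C(=O)c2ccncc2Nc2cc(-c3ccc4ccn(C)c4c3)c3nccnc3c2)C1` differs from compound 1 by 1-methylpyrrolidin-3-yl in place of hydrogen on an amide-type nitrogen. The measured steps touch the same amide nitrogen but replace the methyl while keeping the amide hydrogen: a 1.2-fold lower number from compound 1 to compound 2 (0.08 log units; within the scatter), a 1.4-fold higher number from compound 1 to compound 3 (0.15 log units; within the scatter) and a 1.7-fold higher number from compound 2 to compound 3 (0.23 log units; within the scatter). For the measured compounds named here, no measured step replaces the amide hydrogen itself. As all three steps stay within the scatter, the expected change is a 1.4-fold higher number from compound 1 to compound 4 (0.16 log units; within the scatter), and compound 4 is estimated at 120 nM, within 50 nM to 350 nM.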

Compound 4, half-maximal inhibitory concentration: 176 nM
Beside the measured number, compound 4's estimate is 1.5-fold (0.17 log units) below it; the range from low to high includes it.
By their numbers in this assay, from the lowest: compounds 2, 1, 3 and 4 (each within the scatter of the next, the first and the last beyond it).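

For the compounds shown here, replacing the amide hydrogen gives the first step at this nitrogen beyond the scatter (a 2.1-fold higher number from compound 1 to compound 4 (0.33 log units; beyond the scatter)), and the gap to the 2-oxopiperidin-4-yl amide also lies beyond it (a 2.6-fold higher number from compound 2 to compound 4 (0.41 log units; beyond the scatter)), while the gap to the 1-methyl-6-oxopiperidin-3-yl amide stays within it (a 1.5-fold higher number from compound 3 to compound 4 (0.18 log units; within the scatter)). Both steps beyond the scatter are modest, so methyl(1-methylpyrrolidin-3-yl)amino on the carbonyl carbon costs little. No supporting data bear on the origin of these steps.

Open: whether a plain second methyl on this nitrogen gives the same step, or whether the ring matters. An open chain such as 2-(dimethylamino)ethyl in place of the amide hydrogen would separate these two readings.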